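A few compounds are considered here, and "the series" means these few. Any claim that something is new, unique, unknown or untested is made for them only; others in the source may bear on it.

Measured in an ADME assay on HepG2 cells (Homo sapiens) for inhibition, with a stated time of 48 h; on this read-out higher numbers stand for an effect only at larger amounts of compound and lower numbers for an effect already at smaller amounts:
- compound 1 `Fc1ccc(Nc2nc(NCc3ccccc3)c3ccccc3n2)cc1Cl`: 6300 nM
- compound 2 `Fc1cc(Nc2nc(NCc3ccccc3)c3ccccc3n2)ccc1Cl`: 6600 nM
- compound 3 `CN1CCN(CCNc2nc(Nc3ccc(F)c(Cl)c3)nc3cccnc23)CC1`: 8900 nM

Compounds 1 and 2 share a core and differ only by 4-chloro-3-fluorophenyl in place of 3-chloro-4-fluorophenyl on a nitrogen on an aromatic ring; the step is a 1.0-fold higher number from compound 1 to compound 2 (0.02 log units; within the scatter). Compound 3 carries a different core; the difference between the two cores is not broken down here. Compound 3 and compound 2 give numbers within the scatter of each other, as do compound 3 and compound 1.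

Compound 4 `CN1CCN(CCNc2nc(Nc3ccc(Cl)c(F)c3)nc3cccnc23)CC1` is not yet measured. It differs from compound 3 by 4-chloro-3-fluorophenyl in place of 3-chloro-4-fluorophenyl on a nitrogen on an aromatic ring, and the place is the same as in the pair of compound 1 and compound 2, so this is the same change seen once before. Because the earlier step of a 1.0-fold higher number from compound 1 to compound 2 (0.02 log units; within the scatter) lay within the scatter, the step from compound 3 to compound 4 is expected to be about a 1.0-fold higher number from compound 3 to compound 4 (0.00 log units; within the scatter). Compound 4 is therefore estimated at 9000 nM, with a range from 4500 nM to 18000 nM.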

Compound 4, half-maximal effective concentration: 12300 nM
For compound 4 the middle estimate is 1.4-fold (0.14 log units) below the measured one; measured number inside the range.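

In this assay, 4-chloro-3-fluorophenyl in place of 3-chloro-4-fluorophenyl on the core of compound 3 gives a 1.4-fold higher number from compound 3 to compound 4 (0.14 log units; within the scatter). The step agrees with the one seen on the core of compound 1: the same change on two cores in this assay, a 1.0-fold higher number (0.02 log units; within the scatter) from compound 1 to compound 2 and a 1.4-fold higher number (0.14 log units; within the scatter) from compound 3 to compound 4, 1.3-fold (0.12 log units) apart, within the scatter of two such steps. So on these two cores the change leaves the read-out within the scatter, but two pairs establish no general rule for other cores, and a step this small cannot show any real effect of the change in this assay.

Open, on these data alone, is how the read-out responds when a nitrile or a methoxy group replaces the chlorine or the fluorine on the phenyl. Also open, as far as these compounds go, is whether the same change stays this small on further cores.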